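Swapping Ethyl for Methoxy on the Aryl Group

The source may hold more compounds than are shown below. What is called first, only, known or untested is meant among the compounds shown, and "the series" means these compounds.

Three compounds share one core and differ only in the group attached to an amide-type nitrogen. Compound 1 `O=C(Nc1ccc(Cl)cc1)Nc1cccc(CNc2nccnc2Cl)c1` gives 4980 nM in a functional assay on MGC-803 cells (Homo sapiens) for antiproliferative activity, read by MTT assay, with a stated time of 48 h; a higher number here means a weaker inhibitor, a lower number a stronger inhibitor. Compound 2 `O=C(Nc1cccc(CNc2nccnc2Cl)c1)NC1CCCC1` gives 23400 nM, and compound 3 `CCc1ccccc1NC(=O)Nc1cccc(CNc2nccnc2Cl)c1` gives 9370 nM. Compound 3 thus stands second highest of the three numbers: a 1.9-fold higher number from compound 1 to compound 3 (0.27 log units; within the scatter) stays within the scatter, while a 2.5-fold lower number from compound 2 to compound 3 (0.40 log units; beyond the scatter) is a modest improvement. Compound 4 `COc1ccccc1NC(=O)Nc1cccc(CNc2nccnc2Cl)c1` differs from compound 3 by methoxy in place of ethyl on an aromatic carbon. The step of a 1.9-fold higher number from compound 1 to compound 3 (0.27 log units; within the scatter) bears most directly, as it also exchanged one substituted aromatic group for another on that nitrogen and stayed within the scatter; the larger step of a 2.5-fold lower number from compound 2 to compound 3 (0.40 log units; beyond the scatter) involved a non-aromatic group instead. The expected change is therefore small, a 1.2-fold lower number from compound 3 to compound 4 (0.10 log units; within the scatter), with no clear direction. Compound 4 is expected to give about 7500 nM, within 2500 nM to 22000 nM.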

Compound 4, half-maximal inhibitory concentration: 12200 nM
For compound 4 the middle estimate is 1.6-fold (0.21 log units) below the measured one; the measured number falls inside the stated range.
By their numbers in this assay, from the lowest: compounds 1, 3, 4 and 2 (each within the scatter of the next, the first and the last beyond it).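

Putting methoxy in place of ethyl on this aromatic carbon, ortho to a large group, adds a hydrogen-bond acceptor, yet in this assay the number stays within the scatter: a 1.3-fold higher number from compound 3 to compound 4 (0.11 log units; within the scatter). The 2-methoxyphenyl group also stays within the scatter of cyclopentyl, a 1.9-fold lower number from compound 2 to compound 4 (0.28 log units; within the scatter), but the gap from 4-chlorophenyl goes beyond it, a 2.4-fold higher number from compound 1 to compound 4 (0.39 log units; beyond the scatter). No measurement is available that would explain these results.

From the compounds shown here alone, whether an amine, a hydroxyl or a longer chain such as propoxy on this carbon would move the number beyond the scatter stays open. So does whether ethyl and methoxy would stay this close on another carbon of the ring.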